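A triazole gives way to a hydroxyphenoxy group

The source may report more compounds than this note shows. Statements on the series, on what has been measured and on what is new or still open speak of the compounds shown alone.

Measured in a functional assay on RAW264.7 cells (Mus musculus) for inhibition, read by Griess assay, with stated times of 3 h and 24 h; on this read-out higher numbers stand for weaker inhibition and lower numbers for stronger inhibition:
- compound 1 `C=C1CCC2[C@](C)(CO)[C@H](O)CC[C@@]2(C)[C@@H]1CCn1ccc(=O)[nH]c1=O` gives > 100000 nM
- compound 2 `C=C1CCC2[C@](C)(CO)[C@H](O)CC[C@@]2(C)[C@@H]1CCn1ccnc1` gives > 50000 nM
- compound 3 `C=C1CCC2[C@](C)(CO)[C@H](O)CC[C@@]2(C)[C@@H]1CCn1cncn1` gives > 100000 nM

Compound 3 stands at > 100000 nM, which is a limit and not a number. Compound 1 and compound 2 also have only limits, so none of the three has a true half-maximal value.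

Compound 4 `C=C1CCC2[C@](C)(CO)[C@H](O)CC[C@@]2(C)[C@@H]1CCOc1ccccc1O` differs from compound 3 in one place: 2-hydroxyphenoxy in place of 1H-1,2,4-triazol-1-yl on a saturated chain carbon, two bonds along the chain from a saturated ring carbon.

The closest measured evidence is a step that the two limits leave unreadable from compound 2 to compound 3. The other two changes at this place are a step that the two limits leave unreadable from compound 1 to compound 3 and a step that the two limits leave unreadable from compound 1 to compound 2. None of these steps has a readable size, so they give no firm guide to the new group.

A step towards stronger inhibition in this assay is therefore expected only tentatively, and compound 4 may also end at a limit. The expected change is an at least 2.5-fold lower number from compound 3 to compound 4 (0.39 log units; beyond the scatter). Compound 4 is estimated at 40000 nM, with an expected range of 8000 nM to 150000 nM.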

Compound 4, half-maximal inhibitory concentration: 47700 nM
For compound 4 the middle estimate is 1.2-fold (0.08 log units) below the measured one, within the range that was stated.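

Among the compounds shown here, with the 2-hydroxyphenoxy group on this saturated chain carbon, compound 4 is the first compound here to give a true half-maximal value in this assay, and the only one of the four with an aromatic ring of carbon only. The change gives an at least 2.0-fold lower number from compound 3 to compound 4 (0.32 log units; beyond the scatter) and an at least 2.0-fold lower number from compound 1 to compound 4 (0.32 log units; beyond the scatter), whereas an at least 1.0-fold lower number from compound 2 to compound 4 (0.02 log units; that floor lies within the scatter) has a floor that does not separate compound 4 from the imidazole compound. Each of these steps is only a floor, and two of them start from the same limit: the limit of > 100000 nM in this assay, at which 2 of the 4 values shown sit.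

On these data alone, it remains open what a plain phenoxy group, without the hydroxyl, or a methoxyphenoxy group would give, and so which part of the new group matters. As far as these compounds go, whether a longer chain carrying the same group would shift the value also remains open.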